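This account rests on a few compounds, and the source may have more. Where it says the series, first, only, none or still open, it means among the compounds named here.

Measured so far in a functional assay on cells (Neutrophil, Homo sapiens) for inhibition, with a stated time of 10 min; on this read-out lower numbers stand for stronger inhibition and higher numbers for weaker inhibition:
Compound 1 `CCOC(=O)c1cnn(CC(C)O)c1NC(=O)Nc1ccc(F)cc1`: in this assay compound 1 gives only a limit, > 10 nM.
Compound 2 `CCCC(O)Cn1ncc(C(=O)OCC)c1NC(=O)NC(C)C`: in this assay compound 2 gives 20 nM.
Compound 3 `CCOC(=O)c1cnn(CC(O)CC)c1NC(=O)Nc1cccc2ccccc12`: in this assay compound 3 gives 12 nM.

Compound 1 stands on the numbers only as a limit (the limit of > 10 nM in this assay, at which 1 of the 3 values shown sits). Within the data shown here, no number is known for it, and no pair of measured compounds differs in a single place, so no measured step is available as a yardstick.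

Compound 4 `CCOC(=O)c1cnn(CC(O)CC)c1NC(=O)Nc1ccc(F)cc1` differs from compound 1 by methyl in place of hydrogen on a saturated chain carbon, two bonds along the chain from an oxygen on a saturated carbon. The chain of compound 4 thereby matches the chain of compound 3, which carries the 2-hydroxybutyl group and gives 12 nM in this assay. Compound 2, with a chain of the same kind lengthened further, sits at 20 nM. Both of these numbers lie close to the limit reported for compound 1, and nothing in the measured set separates the effect of the chain from the effect of the other substituent.

Among the measured compounds shown here, no measured step covers this change. The step from compound 1 to compound 4 is expected to be small, within the scatter, with no direction that can be read from the data. Compound 4 is therefore expected near 15 nM in this assay, with a range from 6 nM to 40 nM, corresponding to a step that the limit leaves unreadable from compound 1 to compound 4.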

Compound 4, half-maximal inhibitory concentration: 3.2 nM
The estimate for compound 4 lay 4.7-fold (0.67 log units) above the measured number; measured number below the stated range.
By their numbers in this assay, from the lowest: compound 4; then compounds 3 and 2 (each within the scatter of the next).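

In this assay, methyl in place of hydrogen on a saturated chain carbon, two bonds along the chain from an oxygen on a saturated carbon, gives an at least 3.1-fold lower number from compound 1 to compound 4 (0.49 log units; beyond the scatter). Among these compounds, this is the only readable step so far, and it shows that this position of the chain is not silent: going from 2-hydroxypropyl to 2-hydroxybutyl, with the rest of the molecule unchanged, moves the read-out beyond the scatter, towards stronger inhibition, from a change of a single carbon. The value for compound 1 is a limit, so the step fixes only a smallest size and its true size remains unknown: the limit of > 10 nM in this assay, at which 1 of the 4 values shown sits.

On these data alone, whether the trend continues with a longer chain such as 2-hydroxypentyl, or with a branched chain at the same carbon, remains open, as does whether an amine or a methoxy group in place of the hydroxyl would keep the lower number. Among the compounds shown here, also open is whether the same methyl gives a step of similar size when the rest of the molecule differs, since this single pair is the only evidence for the change.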